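Swapping the Para Group on the Cinnamamide Phenyl

The compounds below may be only part of what the source reports. "The series", "measured", "known", "first", "only" and "open" are said of these compounds alone.

Compound 2 `COc1ccc(C(=O)c2cc(OC)c(OC)c(OC)c2)cc1NC(=O)/C=C/c1ccc(C(F)(F)F)cc1` gives the lowest of the two numbers measured in a functional assay on PC-3 cells (Homo sapiens) for cytotoxicity, read by MTT assay, with a stated time of 72 h (on this read-out lower numbers stand for stronger inhibition and higher numbers for weaker inhibition), namely 3500 nM. Compound 1 `COc1ccc(C(=O)c2cc(OC)c(OC)c(OC)c2)cc1NC(=O)/C=C/c1ccc(OC)c(OC)c1` gives 7500 nM in this assay, and the step of a 2.1-fold lower number from compound 1 to compound 2 (0.33 log units; beyond the scatter) is the only one measured. Compound 3 `COc1ccc(C(=O)c2cc(OC)c(OC)c(OC)c2)cc1NC(=O)/C=C/c1ccc([N+](=O)[O-])cc1` differs from compound 2 by nitro in place of trifluoromethyl on an aromatic carbon. Within the data shown here, no measured step touches this change; the step from compound 1 to compound 2 concerns a different group at the same place and bears on it only loosely. A step of no change at the digits printed from compound 2 to compound 3 (within the scatter) is therefore expected, with no change beyond the scatter. Compound 3 is estimated at 3500 nM, within 1200 nM to 10000 nM.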

Compound 3, half-maximal inhibitory concentration: 10400 nM
Compound 3: the middle estimate sits 3.0-fold (0.47 log units) below what was measured; measured number above the stated range.
By their numbers in this assay, from the lowest: compound 2; then compounds 1 and 3 (each within the scatter of the next).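

In this assay the group on this aromatic carbon, para to a large group, is not interchangeable: nitro in place of trifluoromethyl gives a 3.0-fold higher number from compound 2 to compound 3 (0.47 log units; beyond the scatter) and so loses what trifluoromethyl had gained. Nitro shows no such gain over the 3,4-dimethoxyphenyl compound, with a 1.4-fold higher number from compound 1 to compound 3 (0.14 log units; within the scatter) as its step. Nothing on hand explains why these two groups part. On these data alone, whether an amine, a carboxylic acid or a nitrile at this place would stand with trifluoromethyl or with nitro stays open.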